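Amine swap at the thiocarbonyl carbon: working notes

The source may report more compounds than this note shows. Statements on the series, on what has been measured and on what is new or still open speak of the compounds shown alone.

Among the measured compounds shown here, compound 1 `S=C(SCc1nc2ccccc2[nH]1)N1CCCCC1` and compound 2 `O=C(CC(SC(=S)N1CCOCC1)c1ccccc1)c1ccccc1` are the two measured members. In a functional assay on the whole organism for inhibition, with Cicer arietinum as the target, with a stated time of 7 days (a lower number here means a stronger inhibitor, a higher number a weaker inhibitor), compound 1 gives 1660 nM, and in this assay compound 2 gives 1650 nM; the two numbers lie within the scatter of each other, so compound 2 stands level with compound 1. Compound 3 `CCN(CC)C(=S)SC(CC(=O)c1ccccc1)c1ccccc1` differs from compound 2 in one place: diethylamino in place of morpholin-4-yl on a thiocarbonyl carbon. For the measured compounds named here, no measured pair shows this change, so no step beyond the scatter is expected in either direction. Compound 3 is estimated at 1600 nM in this assay, range 600 nM to 4500 nM. The expected step is a 1.0-fold lower number from compound 2 to compound 3 (0.01 log units; within the scatter).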

Compound 3, half-maximal inhibitory concentration: 1840 nM
Beside the measured number, compound 3's estimate is 1.2-fold (0.06 log units) below it; measured number inside the range.
By their numbers in this assay, from the lowest: compounds 2, 1 and 3 (each within the scatter of the next).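

Among the compounds shown here, the step of a 1.1-fold higher number from compound 2 to compound 3 (0.05 log units; within the scatter) in this assay is the first measured change at this position. On a thiocarbonyl carbon whose other neighbours are sulfur, the open diethylamino group stands level with the morpholin-4-yl ring, so in this pair neither the ring nor its oxygen is needed to hold the number. No supporting data bear on why these two groups stand level.

Going by these compounds, whether piperazin-1-yl or a smaller group such as dimethylamino would also stay level on this carbon remains open. So does the effect of a carboxylic acid on either phenyl ring of the shared core.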